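This account rests on a few compounds, and the source may have more. Where it says the series, first, only, none or still open, it means among the compounds named here.

Measured compounds in a functional assay on A549 cells (Homo sapiens) for cytotoxicity, read by MTT assay, with a stated time of 72 h; a lower number here means a stronger inhibitor, a higher number a weaker inhibitor:
- compound 1 `CN(C)CCn1cnnc1-c1cc(Oc2ccc(NC(=O)N/N=C/c3c(Cl)cccc3Cl)cc2F)ccn1`: 1410 nM
- compound 2 `COc1ccc(/C=N/NC(=O)Nc2ccc(Oc3ccnc(-c4nncn4CCN(C)C)c3)c(F)c2)cc1O`: > 100000 nM

Compound 2 stands at the top end of what was observed here: in this assay compound 2 gives > 100000 nM, which is a limit of the assay and not a number, as noted in the limit of > 100000 nM in this assay, at which 1 of the 2 values shown sits. Within the data shown here, compound 1 is the only compound with a firm value, and the single measured step is an at least 70-fold higher number from compound 1 to compound 2 (1.85 log units; beyond the scatter); it shows that the aryl group on the carbon with a double bond to nitrogen governs a large part of the potency.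

Compound 3 `Cc1cc(/C=N/NC(=O)Nc2ccc(Oc3ccnc(-c4nncn4CCN(C)C)c3)c(F)c2)cc(C)c1O` is not yet measured. It differs from compound 2 in one place: 4-hydroxy-3,5-dimethylphenyl in place of 3-hydroxy-4-methoxyphenyl on a carbon with a double bond to nitrogen. A phenol is kept, the methoxy leaves and two methyls enter. Among the measured compounds shown here, no measured step tests this exchange directly; the one step that does touch this position, from compound 1 to compound 2, ran between two quite different aryl groups, so it gives only the direction of risk, not the size. Compound 3 is therefore expected to remain weak in this assay, with the expected step from compound 2 being an at least 1.6-fold lower number from compound 2 to compound 3 (0.22 log units; that floor lies within the scatter), quite possibly none beyond the scatter. Compound 3 is estimated at 60000 nM, within 8000 nM to 150000 nM.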

Compound 3, half-maximal inhibitory concentration: 1640 nM
The estimate for compound 3 lay 37-fold (1.56 log units) above the measured number; the measured number lies below the stated range.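

In this assay, the exchange of 3-hydroxy-4-methoxyphenyl for 4-hydroxy-3,5-dimethylphenyl on the carbon with a double bond to nitrogen gives an at least 60-fold lower number from compound 2 to compound 3 (1.78 log units; beyond the scatter), so the presence of a phenol does not settle the outcome at this position, and neither does the hydrogen-bond donor count or the heavy-atom count, which both groups share. Compound 2 gives > 100000 nM, which is a limit and not a number, so the size of that step is only a floor. The exchange of 2,6-dichlorophenyl for 4-hydroxy-3,5-dimethylphenyl gives a 1.2-fold higher number from compound 1 to compound 3 (0.07 log units; within the scatter), so among the three aryl groups shown, chlorine atoms are not required for a value of this order, and compound 2 is the one compound that stands apart.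

The compounds shown leave open which part of the exchange carries the step: the loss of the methoxy, the entry of the two methyls, or the change from 3-hydroxy to 4-hydroxy. They also leave open whether an amine or a carboxylic acid in place of the hydroxy group of compound 3 would keep a value like that of compound 3, 1640 nM.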